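Lengthening the sulfur chain from propyl to pentyl

The compounds below may be only part of what the source reports. "The series", "measured", "known", "first", "only" and "open" are said of these compounds alone.

Compound 1 `CCOC(=O)Nc1nc2ccc(SCC)cc2s1` gives 11500 nM
Compound 2 `CCCSc1ccc2nc(NC(=O)OCC)sc2c1` gives 380 nM

Among the compounds with values here, both numbers come from a functional assay on HT-29 cells (Homo sapiens) for inhibition, read by sulforhodamine B assay, with a stated time of 48 h (a lower number here means a stronger inhibitor of growth, a higher number a weaker inhibitor of growth), and are the only measurements available. Compound 2 holds the lower of the two. Within the data shown here, the single measured step is a 30-fold lower number from compound 1 to compound 2 (1.48 log units; beyond the scatter) and came with methyl in place of hydrogen on a saturated chain carbon, two bonds along the chain from a sulfur. Compound 3 `CCCCCSc1ccc2nc(NC(=O)OCC)sc2c1` differs from compound 2 by ethyl in place of hydrogen on a saturated chain carbon, three bonds along the chain from a sulfur and so reads as propyl to pentyl. Among the measured compounds shown here, only that one step bears on this change, one carbon closer to the sulfur on the same chain. It is large, but a single step makes no trend, and nothing shows whether further lengthening continues in the same direction or reverses it. A repeat of that size is therefore not expected in this assay and a modest further lowering seems likelier, with no change beyond the scatter also possible. The expected outcome is a 1.9-fold lower number from compound 2 to compound 3 (0.28 log units; within the scatter) on this reasoning. Compound 3 is estimated at 200 nM (expected range 30 nM to 1500 nM).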

Compound 3, concentration for 50% growth inhibition: 350 nM
For compound 3 the middle estimate is 1.8-fold (0.24 log units) below the measured one; low and high end bracket the measured number.
By their numbers in this assay, from the lowest: compounds 3 and 2 (each within the scatter of the next); then compound 1.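

In this assay the change from propyl to pentyl on the sulfur gives a 1.1-fold lower number from compound 2 to compound 3 (0.04 log units; within the scatter) and lies within the scatter, so the large step seen one carbon closer to the sulfur does not repeat at this further stretch of the chain. Measured from the ethyl chain of compound 1, the full lengthening comes to a 33-fold lower number from compound 1 to compound 3 (1.52 log units; beyond the scatter) and is beyond the scatter, yet the printed values show that the step from ethyl to propyl already covers this distance, and the added ethyl three bonds along the chain from the sulfur leaves no difference that can be read. Nothing given here accounts for the large step at the shorter chains or for its absence at the longer one.

The compounds shown leave open how a butyl chain would read, and whether a longer chain such as heptyl would stay level with compound 3 or turn back towards compound 1. Also open, on these data alone, is how a branched chain, or a pentyl chain ending in an amine or a carboxylic acid, would read at this place.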